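The source may report more compounds than this note shows. Statements on the series, on what has been measured and on what is new or still open speak of the compounds shown alone.

Compound 1 `CC/C=C/CC(=O)OCC1COCCOCCOCCOCCOCCO1` and compound 2 `O=C(CCCCOc1ccccc1)OCC1COCCOCCOCCOCCOCCO1` share one core and differ only in the ester chain. In a functional assay on HeLa cells (Homo sapiens) for inhibition, read by sulforhodamine B assay, with a stated time of 48 h (on this read-out higher numbers stand for weaker inhibition of growth and lower numbers for stronger inhibition of growth), compound 1 gives only a limit of > 100000 nM. In this assay compound 2 also gives only a limit of > 100000 nM. The step that the two limits leave unreadable from compound 1 to compound 2 cannot be sized, since both values sit at the limit of > 100000 nM in this assay, at which 2 of the 2 values shown sit. Compound 3 `O=C(CCCCc1ccccc1)OCC1COCCOCCOCCOCCOCCO1` differs from compound 2 by phenyl in place of phenoxy on a saturated chain carbon, four bonds along the chain from a carbonyl carbon. Among the compounds with values here, no measured step bears on this change, and both measured neighbours sit at the limit. Compound 3 is therefore expected to stay near that limit, with an expected step that the limit leaves unreadable from compound 2 to compound 3. The estimate for compound 3 in this assay is 150000 nM, expected between 40000 nM and 600000 nM.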

Compound 3, concentration for 50% growth inhibition: 52000 nM
Beside the measured number, compound 3's estimate is 2.9-fold (0.46 log units) above it, within the range that was stated.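

In this assay, compound 3 is the first compound shown to give a number rather than a limit, so phenyl in place of phenoxy now has a step with a floor: an at least 1.9-fold lower number from compound 2 to compound 3 (0.28 log units; that floor lies within the scatter). The change to 3-phenylpropyl in place of but-1-en-1-yl reads the same way: an at least 1.9-fold lower number from compound 1 to compound 3 (0.28 log units; that floor lies within the scatter). Neither floor shows a change beyond the scatter, and the other two values remain limits: the limit of > 100000 nM in this assay, at which 2 of the 3 values shown sit.

As far as these compounds go, the true size of both steps stays open. Also open, from the compounds shown here alone, is whether a longer chain, or an amine or a carboxylic acid in place of phenyl, would move the number.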